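From Furan-2-yl to Pyridin-4-yl on the Shared Core

The compounds below may be only part of what the source reports. "The series", "measured", "known", "first", "only" and "open" are said of these compounds alone.

Compound 1 `Oc1cccc(-c2cc(-c3ccccc3)cc(-c3cccs3)n2)c1`: 51.2%
Compound 2 `Oc1cccc(-c2cc(-c3ccccc3)cc(-c3ccco3)n2)c1`: 10.2%

In an assay on isolated protein for inhibition of DNA topoisomerase 1 (Homo sapiens), with a stated time of 30 min, tested at 100 uM (a lower number here means a weaker effect, a higher number a stronger effect of the compound at the concentration tested), compound 2 gives 10.2%, the lowest of the two numbers measured; its nearest neighbour is compound 1, and the step of a number 41 percentage points lower from compound 1 to compound 2 (beyond the scatter) shows how far the two lie apart. Compound 3 `Oc1cccc(-c2cc(-c3ccccc3)cc(-c3ccncc3)n2)c1` has not been measured. It differs from compound 2 in one place: pyridin-4-yl in place of furan-2-yl on an aromatic carbon. For the measured compounds named here, the only measured step, a number 41 percentage points lower from compound 1 to compound 2 (beyond the scatter), exchanges one five-membered ring for another and so bears only loosely on an exchange for a six-membered ring with one nitrogen. That step was large, which shows the position is sensitive to the ring placed there. A return toward the level of compound 1 is therefore plausible but far from assured. Compound 3 is expected at 28%, with a range from 5% to 55%, which means an expected step of a number 17.8 percentage points higher from compound 2 to compound 3 (beyond the scatter).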

Compound 3, a percentage reported as inhibition, at one concentration (the size of the read-out at that concentration, not a potency): 70.4%
Estimate against measurement, compound 3: 42.4 percentage points below, outside the stated range (above it).
By their numbers in this assay, from the lowest: compound 2; then compound 1; then compound 3.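

The two new steps show that this position on the shared core accepts a six-membered aromatic ring as well as five-membered ones, and that the ring placed there can move the read-out in this assay in either direction. The step of a number 60.2 percentage points higher from compound 2 to compound 3 (beyond the scatter) is large, while the step of a number 19.2 percentage points higher from compound 1 to compound 3 (beyond the scatter) is modest yet still beyond the scatter, so pyridin-4-yl stands above both five-membered rings and compound 3 gives the highest number of the three. Nothing available here explains why these rings differ.

The compounds shown leave open whether pyridin-3-yl or pyridin-2-yl, with the ring nitrogen elsewhere, would match pyridin-4-yl, or whether plain phenyl at this place would do as well. They also leave open how a pyridin-4-yl ring carrying an amine or a carboxylic acid would read.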